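Moving the thiophene attachment point: expected cytotoxicity

The compounds below may be only part of what the source reports. "The series", "measured", "known", "first", "only" and "open" are said of these compounds alone.

Measured so far:
compound 1, `Cc1cc(-c2ccccc2)c2ncc(CSCCc3ccccc3)n2c1`, which in an ADME assay on HEL cells (Homo sapiens) for cytotoxicity, with a stated time of 3 days (a higher number here means that more compound is tolerated, a lower number that less compound is tolerated), gives 20 ug/mL
compound 2, `Cc1cc(-c2ccsc2)c2ncc(CSCCc3ccccc3)n2c1`, which in this assay gives 100 ug/mL

Among the compounds with values here, compound 2 stands at the highest of the two numbers recorded in this assay; its only neighbour is compound 1, and the step of a 5.0-fold higher number from compound 1 to compound 2 (0.70 log units; beyond the scatter) lies beyond the scatter. Compound 3, `Cc1cc(-c2cccs2)c2ncc(CSCCc3ccccc3)n2c1`, has not yet been measured in this assay. It differs from compound 2 by thiophen-2-yl in place of thiophen-3-yl on an aromatic carbon. Within the data shown here, only one measured step exists, a 5.0-fold higher number from compound 1 to compound 2 (0.70 log units; beyond the scatter), and it concerns a different exchange, thiophen-3-yl in place of phenyl, so it offers no direct guide to moving the attachment point within the thiophene ring from thiophen-3-yl to thiophen-2-yl. Among the measured compounds shown here, with the two compounds sharing the same atoms joined differently and no comparable step on record, the expectation is a step of no change at the digits printed from compound 2 to compound 3 (within the scatter) that stays within the usual scatter. Compound 3 is therefore estimated at 100 ug/mL in this assay, with a range from 35 ug/mL to 250 ug/mL.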

Compound 3, minimum cytotoxic concentration: 100 ug/mL
The estimate for compound 3 equals the measured number at the digits printed; low and high end bracket the measured number.
By their numbers in this assay, from the lowest: compound 1; then compounds 2 and 3 (each within the scatter of the next).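

In this assay, the place of attachment within the thiophene ring makes no difference that can be read at this position, an aromatic carbon ortho to a fused ring and meta to a methyl group: thiophen-2-yl in place of thiophen-3-yl gives no change at the digits printed from compound 2 to compound 3 (within the scatter). Thiophen-2-yl in place of phenyl gives a 5.0-fold higher number from compound 1 to compound 3 (0.70 log units; beyond the scatter), so the separation from the phenyl of compound 1, earlier seen for thiophen-3-yl alone, now holds for both thiophene attachments. Nothing available explains why the two thiophenes sit together or why the phenyl compound stands apart from them.

On these data alone, the three compounds carry only phenyl and the two thiophenes at this place, so it remains open whether a pyridine ring, a furan ring or a non-aromatic group such as an amine would stand with the thiophenes, with phenyl or apart from both. As far as these compounds go, it also remains open whether the match between thiophen-2-yl and thiophen-3-yl would persist if the sulfur-containing side chain shared by all three compounds gave way to a shorter chain or a carboxylic acid.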